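This account rests on a few compounds, and the source may have more. Where it says the series, first, only, none or still open, it means among the compounds named here.

Measured so far in a functional assay on MDA-MB-435S cells (Homo sapiens) for cytotoxicity, read by MTT assay; on this read-out higher numbers stand for weaker inhibition and lower numbers for stronger inhibition:
- compound 3 `CCOC(=O)C(C)Oc1cc(O)c2c(=O)c(O)c(-c3ccc(OC)cc3)oc2c1CC=C(C)C`: 2500 nM
- compound 2 `COc1ccc(-c2oc3c(CC=C(C)C)c(OC(C(=O)O)C(=O)O)cc(O)c3c(=O)c2OC(C(=O)O)C(=O)O)cc1`: 78900 nM
- compound 1 `COc1ccc(-c2oc3c(CC=C(C)C)c(OCC(=O)O)cc(O)c3c(=O)c2OCC(=O)O)cc1`: a limit, > 100000 nM

Compound 3 gives the lowest of the two numbers shown, and compound 2 stands well above it, beyond the scatter. For compound 1 the assay reports only (the limit of > 100000 nM in this assay, at which 1 of the 3 values shown sits). Compound 4 `COc1ccc(-c2oc3c(CC=C(C)C)c(OCCCC(=O)O)cc(O)c3c(=O)c2O)cc1` is not yet measured; it differs from compound 3 as follows: 3-carboxypropyl in place of 1-(ethoxycarbonyl)ethyl on an oxygen on an aromatic ring. Compound 2, which carries free carboxylic acids, gives 78900 nM, so the carboxylic acid entering in compound 4 is expected to move the number upward. The step is estimated at a 6.0-fold higher number from compound 3 to compound 4 (0.78 log units; beyond the scatter), a weakening beyond the scatter. Compound 4 is thus expected to give 15000 nM, within a range of 4000 nM to 60000 nM.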

Compound 4, half-maximal inhibitory concentration: 12700 nM
Estimate against measurement, compound 4: 1.2-fold (0.07 log units) above, within the range that was stated.
By their numbers in this assay, from the lowest: compound 3; then compound 4; then compound 2. At a limit, above all of these: compound 1.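

In this assay, within the data shown here, compound 3 and compound 4 give the first comparison of compounds that differ in one place: on an oxygen on an aromatic ring, 3-carboxypropyl in place of 1-(ethoxycarbonyl)ethyl gives a 5.1-fold higher number from compound 3 to compound 4 (0.71 log units; beyond the scatter). This position therefore responds to the change, with weaker inhibition beyond the scatter, although the step is modest. Nothing measured here bears on why the number moves. The compounds shown leave open whether the free carboxylic acid or the chain itself carries the step, which an ethyl ester on the same chain would separate. They also leave open how an amine at the chain end would read.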